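Working notes: from compound 1 to compound 3

The compounds below may be only part of what the source reports. "The series", "measured", "known", "first", "only" and "open" are said of these compounds alone.

Values so far in a physicochemical assay for solubility, at pH 7.4; a higher number here means a more soluble compound, a lower number a less soluble compound:
- compound 1 `Cc1cc(C)c(-c2ncc[nH]2)cc1NC(=O)c1ccc(OCc2ccccn2)cc1` gives 2000 nM
- compound 2 `Cc1cc(F)c(-c2ncc[nH]2)cc1NC(=O)c1ccc(OCc2ccccn2)cc1` gives 1000 nM

Among the compounds with values here, compound 1 cannot be separated from compound 2, the only other measured compound: the data show a 2.0-fold lower number from compound 1 to compound 2 (0.30 log units; within the scatter) for fluoro in place of methyl on an aromatic carbon. Within the data shown here, compound 3 `Cc1cc(C)c(-c2c[nH]nc2C)cc1NC(=O)c1ccc(OCc2ccccn2)cc1` instead carries 3-methyl-1H-pyrazol-4-yl in place of 1H-imidazol-2-yl on an aromatic carbon and no measured step touches that group. Among the measured compounds shown here, the one step therefore sets no direction and only a rough size. In this assay the expected change is a 1.3-fold lower number from compound 1 to compound 3 (0.12 log units; within the scatter) and nothing beyond the scatter is expected. For compound 3 the estimated value is 1500 nM with an expected range from 400 nM to 5000 nM.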

Compound 3, solubility: 33000 nM
Compound 3: middle estimate off by 22-fold (1.34 log units), on the low side; the measured number lies above the stated range.
By their numbers in this assay, from the lowest: compounds 2 and 1 (each within the scatter of the next); then compound 3.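

The position carrying the five-membered ring responds strongly in this assay: 3-methyl-1H-pyrazol-4-yl in place of 1H-imidazol-2-yl gives a 17-fold higher number from compound 1 to compound 3 (1.22 log units; beyond the scatter). The groups leaving and entering have the same hydrogen-bond donor and acceptor counts and no net charge, so a large step occurs here without a change in any of these. Nothing available explains the step.

Open, as far as these compounds go, is whether the step follows the pyrazole ring or its methyl group, a question for the unsubstituted 1H-pyrazol-4-yl group. Also open, from the compounds shown here alone, is whether an aminomethyl group on that ring extends the step.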